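The compounds below may be only part of what the source reports. "The series", "measured", "known", "first", "only" and "open" are said of these compounds alone.

Measured compounds in a functional assay on SK-LU-1 cells (Homo sapiens) for antiproliferative activity, read by sulforhodamine B assay, with a stated time of 48 h, tested at 50 uM; on this read-out lower numbers stand for less inhibition and higher numbers for more inhibition at the one concentration tested (going by the name of the read-out):
- Compound 1 `COc1ccc(C(=O)Oc2cc3c(cc2C)[C@@H](C(C)C)CC=C3C)cc1` gives 18.6%
- Compound 2 `CC1=CC[C@H](C(C)C)c2cc(C)c(OC(=O)c3cccc(C)c3)cc21` is reported as "not active" (no number reported), with no number attached
- Compound 3 `COc1ccc(C(=O)Oc2cc3c(C)ccc(C(C)C)c3cc2C)cc1` gives 32.8%

Of the two compounds with a number, compound 3 stands highest in this assay: compound 1 sits below it by a gap that is beyond the usual scatter of repeated measurements, and compound 2 contributes only a verbal report without a figure. Compound 4 `Cc1cc2c(C(C)C)ccc(C)c2cc1OC(=O)c1ccc(C(F)(F)F)cc1` has not been measured yet. It differs from compound 3 in one place: trifluoromethyl in place of methoxy on an aromatic carbon. The exchange sits on an aromatic carbon of a six-membered aromatic ring of carbon only, para to a large group.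

Going by the values given here, no pair of measured compounds shows this exchange, so the size and direction of the step cannot be taken from anything measured here. The expectation is therefore a modest step, quite possibly one that stays within the scatter, and the estimated step from compound 3 to compound 4 in this assay is a number 3.2 percentage points higher from compound 3 to compound 4 (within the scatter). Compound 4 is expected to give about 36%, with a plausible range from 15% to 57%, because compound 3 provides the only direct anchor at 32.8%.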

Compound 4, a percentage reported as inhibition, at one concentration (the size of the read-out at that concentration, not a potency): 28.7%
Compound 4: middle estimate off by 7.3 percentage points, on the high side; the range from low to high includes it.
By their numbers in this assay, from the lowest: compound 1; then compounds 4 and 3 (each within the scatter of the next).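

In this assay, going by these compounds alone, the exchange of methoxy for trifluoromethyl, on an aromatic carbon para to a large group, gives a number 4.1 percentage points lower from compound 3 to compound 4 (within the scatter) and is the first direct reading of any change at this place. At the single concentration tested, the read-out therefore does not separate these two groups, even though the heavy atoms of the group rise from 2 to 4 and the hydrogen-bond acceptor counted on methoxy is absent from trifluoromethyl. Nothing measured here points to an explanation for this small step, so the result stands as an observation only.

This single pair cannot show whether the same place would accept a quite different group, such as an amine, a carboxylic acid or a longer chain, without a step beyond the scatter. It also leaves open whether trifluoromethyl in place of methoxy would give a similar result on the core of compound 1, and how either compound 3 or compound 4 would behave across a range of concentrations.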